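The source may hold more compounds than are shown below. What is called first, only, known or untested is meant among the compounds shown, and "the series" means these compounds.

Measured compounds:
- compound 1 `CCCn1c(=O)c2nc(-c3cnn(Cc4cc(Cl)ccc4Cl)c3)[nH]c2n(CCC)c1=O` — in an in vitro assay on HEK293 cells for displacement of a labelled ligand from adenosine receptor A2b (Homo sapiens) (on this read-out lower numbers stand for stronger inhibition and higher numbers for weaker inhibition), compound 1 gives 29 nM
- compound 2 `CCCn1c(=O)c2nc(-c3cnn(Cc4cccc(F)c4F)c3)[nH]c2n(CCC)c1=O` — in this assay compound 2 gives 240 nM

Going by the values given here, compound 2 stands as the higher of the two numbers so far; its nearest neighbour is compound 1, and the only step, an 8.3-fold higher number from compound 1 to compound 2 (0.92 log units; beyond the scatter), places compound 2 well apart from compound 1.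

The next compound, compound 3 `CCCn1c(=O)c2nc(-c3cnn(Cc4ccccc4C)c3)[nH]c2n(CCC)c1=O`, is reached from compound 2 by 2-methylphenyl in place of 2,3-difluorophenyl on a saturated chain carbon bound to an aromatic nitrogen. Among the compounds with values here, only one measured step bears on this change, an 8.3-fold higher number from compound 1 to compound 2 (0.92 log units; beyond the scatter), and it exchanged one substituted phenyl for another at the same place. Compound 3 carries a 2-methylphenyl, which is neither of the two phenyls already measured, so the direction of the step is not fixed by the data. Within the data shown here, the one step seen shows that swapping the group at this place can move the number well beyond the scatter.

A step of a 2.4-fold lower number from compound 2 to compound 3 (0.38 log units; beyond the scatter) in this assay is expected for compound 3. Compound 3 is estimated at 100 nM, with a range of 30 nM to 400 nM.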

Compound 3, inhibition constant: 33 nM
Estimate against measurement, compound 3: 3.0-fold (0.48 log units) above; low and high end bracket the measured number.
By their numbers in this assay, from the lowest: compounds 1 and 3 (each within the scatter of the next); then compound 2.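

In this assay, the change from 2,3-difluorophenyl to 2-methylphenyl on a saturated chain carbon bound to an aromatic nitrogen gives a 7.3-fold lower number from compound 2 to compound 3 (0.86 log units; beyond the scatter), so the number at this place can move in the favourable direction as well as the unfavourable, and a halogen on the phenyl is not required for a number as low as that of compound 1. Going by these compounds alone, exchanging 2,5-dichlorophenyl for 2-methylphenyl gives a 1.1-fold higher number from compound 1 to compound 3 (0.06 log units; within the scatter), which leaves those two groups indistinguishable on this read-out and makes compound 2, with the 2,3-difluorophenyl, the one compound of the three that stands apart from both others. No measurement at hand accounts for the separation of the 2,3-difluorophenyl from the other two groups.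

With three differently substituted phenyls, the compounds shown do not tell whether the higher number of compound 2 goes with the fluorine atoms or with their placement. A plain phenyl, a 2-fluorophenyl and a 2,3-dichlorophenyl on the same carbon remain the open comparisons, as does the scope for a ring other than phenyl, such as a pyridine.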